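A few compounds are considered here, and "the series" means these few. Any claim that something is new, unique, unknown or untested is made for them only; others in the source may bear on it.

Working notes on the series. All three measured compounds share one core and differ only at the carbonyl carbon: compound 1 `COCCOC(=O)c1cc(N)c(Nc2ccc(C#N)cc2)cc1Oc1c(C)cc(/C=C/C#N)cc1C` carries a 2-methoxyethoxy group there, compound 2 `Cc1cc(/C=C/C#N)cc(C)c1Oc1cc(Nc2ccc(C#N)cc2)c(N)cc1C(=O)NN` an amino group on the amide-type nitrogen, and compound 3 `Cc1cc(/C=C/C#N)cc(C)c1Oc1cc(Nc2ccc(C#N)cc2)c(N)cc1C(=O)NCCC(F)F` a 3,3-difluoropropyl group at the same nitrogen. In a physicochemical assay for lipophilicity, read by HPLC, measured as octanol-water partition, with a stated time of 24 h, at pH 7.4 (on this read-out lower numbers stand for lower lipophilicity and higher numbers for higher lipophilicity), compound 1 gives > 5, which is a limit of the assay and not a number (the limit of > 5 in this assay, at which 1 of the 3 values shown sits). In this assay compound 2 gives 2.31. In this assay compound 3 gives 3.58, the highest of the two numbers shown, with compound 2 the nearest. Within the data shown here, the single direct comparison at the amide-type nitrogen is a number 1.27 log units higher from compound 2 to compound 3 (beyond the scatter); the steps of a number at least 2.69 log units lower from compound 1 to compound 2 (beyond the scatter) and a number at least 1.42 log units lower from compound 1 to compound 3 (beyond the scatter) start from a limit and give only bounds.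

Compound 4 `Cc1cc(/C=C/C#N)cc(C)c1Oc1cc(Nc2ccc(C#N)cc2)c(N)cc1C(=O)N1CC1` differs from compound 3 by aziridin-1-yl in place of (3,3-difluoropropyl)amino on a carbonyl carbon. Among the measured compounds shown here, the one measured change at that nitrogen, a number 1.27 log units higher from compound 2 to compound 3 (beyond the scatter), is the step that bears on this one, and given the difference in size and donor count just described the expected step is a number 0.58 log units lower from compound 3 to compound 4 (beyond the scatter), a move back toward compound 2 without reaching it. For compound 4 the estimate in this assay is 3, with a range from 2.4 to 3.6.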

Compound 4, partition coefficient: 2.21
Compound 4: middle estimate off by 0.79 log units, on the high side, and the stated range ends above it.
By their numbers in this assay, from the lowest: compounds 4 and 2 (each within the scatter of the next); then compound 3. At a limit, above all of these: compound 1.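

In this assay, the step of a number 1.37 log units lower from compound 3 to compound 4 (beyond the scatter) shows that on this carbonyl carbon a group with 0 hydrogen-bond donors does not have to read higher than the group with 1 that it replaces, and that the number here can fall as far with this change as it rose between the two amide-type compounds. The step of a number 0.10 log units lower from compound 2 to compound 4 (within the scatter) places aziridin-1-yl level with aminoamino, so two unlike groups read alike at this position, while a number at least 2.79 log units lower from compound 1 to compound 4 (beyond the scatter) gives only a bound. Compound 1 remains at a limit of the assay, not a number: the limit of > 5 in this assay, at which 1 of the 4 values shown sits.

From compound 3 to compound 4 the ring, the loss of the fluorine atoms, the loss of the amide hydrogen and the shorter group all arrive in a single change, and the compounds shown do not separate them. As far as these compounds go, a plain propyl group on the amide-type nitrogen would isolate the fluorine atoms, and an azetidin-1-yl or a dimethylamino group on the carbonyl carbon would test the ring and its size; how either would read remains open.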